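Bromophenyl Isomer on Sulfur: An Estimate for Compound 3

A few compounds are considered here, and "the series" means these few. Any claim that something is new, unique, unknown or untested is made for them only; others in the source may bear on it.

Among the compounds with values here, in a functional assay on DU-145 cells (Homo sapiens) for inhibition, read by trypan blue exclusion, with a stated time of 96 h (on this read-out higher numbers stand for weaker inhibition of growth and lower numbers for stronger inhibition of growth), compound 1 (`O=C(/C(=C\c1ccc(Br)cc1)SCc1ccc(Cl)cc1)c1ccc(Br)cc1`) gives 1000 nM and compound 2 (`O=C(/C(=C\c1ccc(Br)cc1)Sc1ccc(Br)cc1)c1ccc(Br)cc1`) gives 1000 nM on the same scale, so compound 2 stands level with the only other compound measured so far. Compound 3 (`O=C(/C(=C\c1ccc(Br)cc1)Sc1ccccc1Br)c1ccc(Br)cc1`) has not yet been measured. Within the data shown here, it has the same atoms as compound 2, joined differently, with 2-bromophenyl in place of 4-bromophenyl on a sulfur as the single structural change.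

Among the measured compounds shown here, only one measured step bears on this sulfur. With 4-bromophenyl in place of 4-chlorobenzyl, it shows no change at the digits printed from compound 1 to compound 2 (within the scatter) as its size. For the measured compounds named here, no measured compound places the bromine anywhere else on the phenyl ring, so this step is an indirect guide and the data cannot settle the matter. On that evidence, no step beyond the scatter is expected in this assay, and no direction is favoured. The expected size is no change at the digits printed from compound 2 to compound 3 (within the scatter) as the estimated step. In this assay the estimated value for compound 3 is 1000 nM with 400 nM to 2500 nM as its expected range.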

Compound 3, concentration for 50% growth inhibition: 1000 nM
The estimate for compound 3 equals the measured number at the digits printed; low and high end bracket the measured number.
By their numbers in this assay, from the lowest: compounds 1, 2 and 3 (each within the scatter of the next).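

Compound 3 gives the first direct test of where the bromine sits on the phenyl ring attached to this sulfur, since the earlier step exchanged 4-chlorobenzyl for 4-bromophenyl and so changed the whole group. In this assay, 2-bromophenyl in place of 4-bromophenyl gives no change at the digits printed from compound 2 to compound 3 (within the scatter), and 2-bromophenyl in place of 4-chlorobenzyl gives no change at the digits printed from compound 1 to compound 3 (within the scatter), so across these three compounds neither the isomer change nor the exchange of the benzyl group for a bromophenyl group separates the read-outs. No measurement shown here offers an account of why these read-outs stand level.

The compounds shown leave open whether 3-bromophenyl, or a phenyl ring carrying an amine or a carboxylic acid, would read differently on this sulfur. They also leave open whether a longer chain on the sulfur, or a plain phenyl without any halogen, would depart from the level seen so far, and so how far this position can be changed before growth inhibition shifts beyond the scatter.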